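A few compounds are considered here, and "the series" means these few. Any claim that something is new, unique, unknown or untested is made for them only; others in the source may bear on it.

Measured compounds:

- compound 1, `CCCCCc1ccc(NS(=O)(=O)c2ccc(N3CCNC3=O)cc2)cc1`: in a functional assay on HT-29 cells (Homo sapiens) for antiproliferative activity, read by sulforhodamine B assay, with a stated time of 48 h (on this read-out lower numbers stand for stronger inhibition and higher numbers for weaker inhibition), compound 1 gives 990 nM.
- compound 2, `O=C1NCCN1c1ccc(S(=O)(=O)Nc2ccc(OC(F)F)cc2)cc1`: in this assay compound 2 gives 650 nM.
- compound 3, `CC(C)Cc1ccc(NS(=O)(=O)c2ccc(N3CCNC3=O)cc2)cc1`: in this assay compound 3 reaches only a limit, > 1000 nM.

Compound 3 therefore stands at the edge of what this assay reports, at the limit of > 1000 nM in this assay, at which 1 of the 3 values shown sits, and no number is known for it. Compound 4, `O=C1NCCN1c1ccc(S(=O)(=O)Nc2ccc(I)cc2)cc1`, differs from compound 3 in one place: iodo in place of isobutyl on an aromatic carbon. For the measured compounds named here, two measured steps touch this position. Going an at least 1.5-fold higher number from compound 2 to compound 3 (0.18 log units; that floor lies within the scatter) took the isobutyl compound to the limit, and going a number no lower from compound 1 to compound 3 (the limit leaves the size open) did likewise, while a 1.5-fold lower number from compound 1 to compound 2 (0.18 log units; within the scatter) stayed within the scatter. The step from compound 3 to compound 4 removes the isobutyl that sits on the limit side of both steps and puts a single-atom iodo in its place. A lower number than the limit of compound 3 is expected, though its size is open since compound 3 itself is only a limit. Compound 4 is expected to give 750 nM, between 300 nM and 3000 nM. That estimate means an expected step of an at least 1.3-fold lower number from compound 3 to compound 4 (0.12 log units; that floor lies within the scatter).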

Compound 4, half-maximal inhibitory concentration: 650 nM
Compound 4: the middle estimate sits 1.2-fold (0.06 log units) above what was measured; the measured number falls inside the stated range.
By their numbers in this assay, from the lowest: compounds 2, 4 and 1 (each within the scatter of the next). At a limit, above all of these: compound 3.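

On these data alone, replacing isobutyl with iodo on this aromatic carbon gives an at least 1.5-fold lower number from compound 3 to compound 4 (0.18 log units; that floor lies within the scatter), so in this assay the position can return to a readable number from the limit, although the true size of the step stays open. Set against the difluoromethoxy and pentyl groups, iodo shows no change at the digits printed from compound 2 to compound 4 (within the scatter) and a 1.5-fold lower number from compound 1 to compound 4 (0.18 log units; within the scatter), so these three groups cannot be told apart here. Compound 3 alone remains at the edge of what the assay reports: the limit of > 1000 nM in this assay, at which 1 of the 4 values shown sits.

The compounds shown leave open whether any group at this position can move the number beyond the scatter of these three. As far as these compounds go, how an amine, a carboxylic acid or a fluoro group would read on this carbon also remains open, as does the actual number of compound 3.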